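The source may hold more compounds than are shown below. What is called first, only, known or untested is meant among the compounds shown, and "the series" means these compounds.

In a functional assay on HO8910 cells (Homo sapiens) for inhibition, read by MTT assay, with a stated time of 24 h, tested at 10 ug/mL (a lower number here means less inhibition of growth, a higher number more inhibition of growth at the concentration tested), compound 1 `O=C(CCCCC1CCSS1)Nc1ccc(OC(F)(F)F)cc1` gives 8.57%. Compound 2 `O=C(CCCCC(CCSC(=O)c1ccccc1)SC(=O)c1ccccc1)Nc1ccccc1` was reported as "not active" (no number reported) in this assay, with no number attached, so where it stands on the scale of percent growth inhibition cannot be placed more closely. Compound 3 `O=C(CCCCC(CCSC(=O)c1ccccc1)SC(=O)c1ccccc1)Nc1cccc(Cl)c1` differs from compound 2 by chloro in place of hydrogen on an aromatic carbon. Within the data shown here, no measured step between two compounds exists to draw on, so no shift in this assay of a size beyond the scatter is expected in either direction. Compound 3 is estimated to give about 10%, with a range from 0% to 30%.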

Compound 3, percent growth inhibition at one concentration: "not active" (no number reported)
Compound 3 has no reported number here, and the estimate cannot be compared.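

Compound 2 and compound 3 are both reported as not active without a number, so no step can be read between them. No evidence bearing on this result is available. Going by these compounds, whether chloro in place of hydrogen changes growth inhibition by any amount stays open.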